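How Far Can the Saturated Chain Stretch?

The compounds below may be only part of what the source reports. "The series", "measured", "known", "first", "only" and "open" are said of these compounds alone.

In a functional assay on NALM-6 cells (Homo sapiens) (on this read-out lower numbers stand for stronger inhibition and higher numbers for weaker inhibition), compound 1 (`CCCCCCCSC[C@H](NC(C)=O)C(=O)CCl`) gives 4800 nM, compound 2 (`CCCCCCCCSC[C@H](NC(C)=O)C(=O)CCl`) gives 5600 nM and compound 3 (`CCCCCCCCCSC[C@H](NC(C)=O)C(=O)CCl`) gives 7300 nM. Compound 3 therefore stands level with its two relatives, since nothing separates the three beyond the usual scatter of repeated measurements.

Compound 4 (`CCCCCCCCCCCCCCCCCCSC[C@H](NC(C)=O)C(=O)CCl`) differs from compound 3 by a single change: nonyl in place of hydrogen on a saturated chain carbon, nine bonds along the chain from a sulfur. For the measured compounds named here, three measured steps bear on this change, each adding only methyl or ethyl to the same saturated chain: a 1.2-fold higher number from compound 1 to compound 2 (0.07 log units; within the scatter), a 1.3-fold higher number from compound 2 to compound 3 (0.12 log units; within the scatter) and a 1.5-fold higher number from compound 1 to compound 3 (0.18 log units; within the scatter). Going by the values given here, all three stay within the scatter, so they offer only a weak hint of direction, and no measured step comes close to an addition as large as nonyl. Taking the sign of a 1.5-fold higher number from compound 1 to compound 3 (0.18 log units; within the scatter) as a cautious guide, a higher number is expected in this assay, meaning weaker inhibition. The expected change is a 2.1-fold higher number from compound 3 to compound 4 (0.31 log units; beyond the scatter). Compound 4 is estimated at 15000 nM, with an expected range from 4000 nM to 50000 nM.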

Compound 4, half-maximal inhibitory concentration: > 100000 nM
Compound 4: a limit, no number; the forecaster's own chance of this, stated with the estimate: 20%; middle value at least 6.6-fold (0.82 log units) from the limit.
By their numbers in this assay, from the lowest: compounds 1, 2 and 3 (each within the scatter of the next). At a limit, above all of these: compound 4.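

The earlier compounds shown here moved only within the scatter, so they gave no clear sign that lengthening the saturated chain matters in this assay. Nonyl in place of hydrogen on a saturated chain carbon, nine bonds along the chain from a sulfur, shows that it can matter: there is an at least 13-fold higher number from compound 3 to compound 4 (1.13 log units; beyond the scatter), a large step well beyond the scatter and in the direction of weaker inhibition. Compound 4 gives a limit of the assay rather than a number: the limit of > 100000 nM in this assay, at which 1 of the 4 values shown sits.

The compounds shown leave open how far compound 4 truly lies from the others and at what intermediate chain length, longer than in compound 3 and shorter than in compound 4, the number starts to climb. They also leave open whether a chain carrying an amine or a carboxylic acid would behave like these plain saturated chains.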